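From Pyridin-3-yl to Piperidin-4-yl at the Amide Carbonyl

A few compounds are considered here, and "the series" means these few. Any claim that something is new, unique, unknown or untested is made for them only; others in the source may bear on it.

Within the data shown here, compound 1, `O=C(c1cccnc1)N1CCC(NS(=O)(=O)c2cc(S(=O)(=O)c3ccccc3)ccc2C(F)(F)F)CC1`, is one of only two compounds measured in an assay on isolated protein for displacement of a labelled ligand from secreted frizzled-related protein 1 (Homo sapiens), read by fluorescence polarization, with a stated time of 30 min (a lower number here means a stronger inhibitor, a higher number a weaker inhibitor), and in that assay compound 1 gives 80 nM. The other measured compound is compound 2, `CC(C)(C)OC(=O)N1CCC(C(=O)N2CCC(NS(=O)(=O)c3cc(S(=O)(=O)c4ccccc4)ccc3C(F)(F)F)CC2)CC1`, and in this assay compound 2 gives 300 nM. Compound 1 therefore stands at the lower of the two numbers, with compound 2 sitting at a higher value that lies well beyond the usual scatter. Among the measured compounds shown here, compounds 1 and 2 differ in more than one place, so no single step between them can be read off.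

Compound 3, `O=C(C1CCNCC1)N1CCC(NS(=O)(=O)c2cc(S(=O)(=O)c3ccccc3)ccc2C(F)(F)F)CC1`, has not yet been measured. It differs from compound 1 in one place: piperidin-4-yl in place of pyridin-3-yl on a carbonyl carbon. Compound 2 already carries a piperidin-4-yl on that carbonyl carbon, with an additional group on its ring nitrogen, and compound 2 shows 300 nM, a higher number than compound 1. For the measured compounds named here, no measured step exists for this exact change, so the direction is uncertain; on the basis of compound 2 a modest weakening is expected, a 2.0-fold higher number from compound 1 to compound 3 (0.30 log units; within the scatter). Compound 3 is accordingly estimated at 160 nM, in a range from 50 nM to 500 nM.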

Compound 3, half-maximal inhibitory concentration: 120 nM
Estimate against measurement, compound 3: 1.3-fold (0.12 log units) above; low and high end bracket the measured number.
By their numbers in this assay, from the lowest: compounds 1 and 3 (each within the scatter of the next); then compound 2.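

In this assay the exchange of pyridin-3-yl for piperidin-4-yl on a carbonyl carbon gives a 1.5-fold higher number from compound 1 to compound 3 (0.18 log units; within the scatter) and so does not separate the aromatic ring from the non-aromatic one, although only the latter carries a hydrogen-bond donor. The second step adds what the two earlier compounds could not show, since they differed in more than one place: hydrogen in place of tert-butoxycarbonyl on an amine nitrogen in a ring gives a 2.5-fold lower number from compound 2 to compound 3 (0.40 log units; beyond the scatter) and thus ties the higher number of compound 2 to the tert-butoxycarbonyl group and not to the piperidin-4-yl ring itself. Nothing available here explains the size of either step.

Still open, going by these compounds, is how smaller groups on the ring nitrogen of piperidin-4-yl, such as methyl or acetyl, would compare with hydrogen and tert-butoxycarbonyl, and whether phenyl or pyridin-4-yl on the same carbonyl carbon would also stay within the scatter of compound 1. On these data alone, the phenylsulfonyl and trifluoromethyl groups are the same in all three compounds, so what replacing either of them, for instance trifluoromethyl by chlorine, would do remains unknown.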